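A few compounds are considered here, and "the series" means these few. Any claim that something is new, unique, unknown or untested is made for them only; others in the source may bear on it.

Measured compounds:
Compound 1 `COc1cc2c(Oc3ccc(NC(=O)c4nn(-c5ccccc5OC(F)(F)F)c(=O)cc4C)cc3F)ccnc2cc1OCCCN1CCCC1` gives 210 nM in a functional assay on NCI-H460 cells (Homo sapiens) for inhibition, read by MTT assay, with a stated time of 72 h; on this read-out lower numbers stand for stronger inhibition and higher numbers for weaker inhibition.
Compound 2 `COc1cc2c(Oc3ccc(NC(=O)c4nn(-c5ccccc5OC(F)(F)F)c(=O)cc4C)cc3F)ccnc2cc1OCCCN1CCCCC1` gives 230 nM in this assay.
Compound 3 `COc1cc2c(Oc3ccc(NC(=O)c4nn(-c5ccccc5OC(F)(F)F)c(=O)cc4C)cc3F)ccnc2cc1OCCCN1CCC(C)CC1` gives 290 nM in this assay.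

Compound 3 holds the highest of the three numbers in this assay, but its gaps to compound 2 and to compound 1 lie within the scatter, so no order among them is claimed. The three measured steps, a 1.1-fold higher number from compound 1 to compound 2 (0.04 log units; within the scatter), a 1.4-fold higher number from compound 1 to compound 3 (0.14 log units; within the scatter) and a 1.3-fold higher number from compound 2 to compound 3 (0.10 log units; within the scatter), all concern the amine at the end of the chain and all stay within the scatter. Compound 4 `COc1ccc(-n2nc(C(=O)Nc3ccc(Oc4ccnc5cc(OCCCN6CCC(C)CC6)c(OC)cc45)c(F)c3)c(C)cc2=O)cc1` differs from compound 3 elsewhere: 4-methoxyphenyl in place of 2-(trifluoromethoxy)phenyl on an aromatic nitrogen. Among the compounds with values here, none of the measured steps touches this position, so they offer no guide to size or direction. Compound 4 is therefore expected to give about 350 nM in this assay, between 120 nM and 1200 nM, which means an estimated step of a 1.2-fold higher number from compound 3 to compound 4 (0.08 log units; within the scatter) with wide uncertainty.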

Compound 4, half-maximal inhibitory concentration: 4650 nM
The estimate for compound 4 lay 13-fold (1.12 log units) below the measured number; measured number above the stated range.
By their numbers in this assay, from the lowest: compounds 1, 2 and 3 (each within the scatter of the next); then compound 4.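

Putting 4-methoxyphenyl in place of 2-(trifluoromethoxy)phenyl on the aromatic nitrogen gives a 16-fold higher number from compound 3 to compound 4 (1.21 log units; beyond the scatter) in this assay and so weaker inhibition, a large step beyond the scatter. This position therefore matters far more in this series than the amine at the end of the chain, where every measured step stayed within the scatter. Nothing measured here says why the step is so large.

Going by these compounds, the change moves the substituent and alters it at once, so 2-methoxyphenyl and 4-(trifluoromethoxy)phenyl remain open as the groups that would separate those two changes. On these data alone, it is also open whether the step holds with pyrrolidin-1-yl or piperidin-1-yl on the chain.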